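Amino in Place of Chloro on a Purine-Like Core

The source may report more compounds than this note shows. Statements on the series, on what has been measured and on what is new or still open speak of the compounds shown alone.

Compound 1 `ClCc1cccc(Cn2cnc3c(Cl)nc(Cl)nc32)c1` was tested in a functional assay on A549 cells (Homo sapiens) for cytotoxicity, read by sulforhodamine B assay, with a stated time of 48 h (a higher number here means that more compound is tolerated, a lower number that less compound is tolerated), where compound 1 gives 52500 nM. Among the compounds with values here, this is the only number in the set: compound 2 `ClCc1ccccc1Cn1cnc2c(Cl)nc(Cl)nc21` was prepared as well, but in this assay compound 2 gives "not determined" (no result reported), so compound 1 stands alone without a comparison. Compound 3 `Nc1nc(Cl)c2ncn(Cc3cccc(CCl)c3)c2n1` has not yet been measured. It differs from compound 1 in one place: amino in place of chloro on an aromatic carbon, on an aromatic carbon of the shared core, between two ring nitrogen atoms. Within the data shown here, no measured pair shows what such a swap does here, so the expectation rests on compound 1 alone. The step from compound 1 to compound 3 is expected to be modest, toward more compound being tolerated, a 1.5-fold higher number from compound 1 to compound 3 (0.18 log units; within the scatter). For compound 3 the estimated value is 80000 nM, with a range from 25000 nM to 250000 nM.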

Compound 3, concentration lethal to 50% of the cells: 63100 nM
For compound 3 the middle estimate is 1.3-fold (0.10 log units) above the measured one, and the stated range covers the measured number.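

On the aromatic carbon of the shared core that lies between two ring nitrogen atoms, amino in place of chloro gives a 1.2-fold higher number from compound 1 to compound 3 (0.08 log units; within the scatter) in this assay. Within the data shown here, this pair offers the first measured look at this position, and the swap does not separate the two compounds, even though the entering amino group carries a hydrogen-bond donor and acceptor that the chloro group lacks. Nothing available explains this result.

A single swap cannot show whether other groups at this position, such as a methoxy group, a dimethylamino group or a longer aminoalkyl chain, would give a step beyond the usual scatter. On these data alone, it also remains open whether amino in place of the remaining chloro group on the core, or a replacement of the chloromethyl group, would give a different result.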